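Replacing 2-fluorophenyl with 5-fluoropyridin-3-yl

The compounds below may be only part of what the source reports. "The series", "measured", "known", "first", "only" and "open" are said of these compounds alone.

Compound 1 `Cc1cnc(Nc2cccc(C(=O)N3CCCC3)c2)nc1N[C@H]1[C@@H](C(N)=O)[C@@H]2C=C[C@H]1C2` gives 100 nM
Compound 2 `NC(=O)[C@@H]1[C@H](Nc2nc(Nc3cccc(C(=O)N4CCCC4)c3)ncc2-c2ccccc2F)[C@H]2C=C[C@@H]1C2` gives 130 nM

Among the measured compounds shown here, both values come from a functional assay on THP-1 cells (Homo sapiens) for inhibition, read by ELISA, with stated times of 1 h and 18 h (a higher number here means a weaker inhibitor, a lower number a stronger inhibitor), and, on these numbers, compound 2 stands within the scatter of compound 1, the only other compound measured. The next compound, compound 3 `NC(=O)[C@@H]1[C@H](Nc2nc(Nc3cccc(C(=O)N4CCCC4)c3)ncc2-c2cncc(F)c2)[C@H]2C=C[C@@H]1C2`, has not yet been measured. It has 5-fluoropyridin-3-yl in place of 2-fluorophenyl on an aromatic carbon of a six-membered aromatic ring with 2 nitrogen, and the change is counted as 5-fluoropyridin-3-yl in place of 2-fluorophenyl on an aromatic carbon in full.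

For the measured compounds named here, one measured step bears on this place. Going by the values given here, it is a 1.3-fold higher number from compound 1 to compound 2 (0.11 log units; within the scatter) for 2-fluorophenyl in place of methyl, so the only change measured at this carbon is a small one. Among the compounds with values here, no measured step exchanges a carbon-only aromatic ring for one with a hetero atom, which leaves the new ring nitrogen without direct evidence. No step beyond the scatter is therefore expected in this assay, and no direction is favoured with any confidence. The estimated step is a 1.1-fold higher number from compound 2 to compound 3 (0.03 log units; within the scatter) on this reasoning. For compound 3 the expected value is 140 nM in a range from 55 nM to 350 nM as estimated here.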

Compound 3, half-maximal inhibitory concentration: 170 nM
Compound 3: middle estimate off by 1.2-fold (0.08 log units), on the low side; the range from low to high includes it.
By their numbers in this assay, from the lowest: compounds 1, 2 and 3 (each within the scatter of the next).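

Among the compounds shown here, in (this assay), 5-fluoropyridin-3-yl is the first ring at this aromatic carbon to carry a hetero atom, and it stays within the scatter of 2-fluorophenyl (a 1.3-fold higher number from compound 2 to compound 3 (0.12 log units; within the scatter)). For the compounds shown here, exchanging the carbon-only ring for one with a ring nitrogen and a hydrogen-bond acceptor therefore gives no step that can be told apart from repeated measurement. The same holds against methyl (a 1.7-fold higher number from compound 1 to compound 3 (0.23 log units; within the scatter)), so methyl, 2-fluorophenyl and 5-fluoropyridin-3-yl all give values within the scatter of one another at this carbon, and nothing measured explains this flat result.

The exchange from compound 2 to compound 3 brings in the ring nitrogen and alters where the fluorine stands on the ring, so the compounds shown cannot separate the contribution of one from that of the other, or show whether the two offset each other. They also leave open whether this carbon would stay equally undemanding with a primary amine, a carboxylic acid or a longer alkyl chain in place of these groups, since all three groups shown fall within the scatter.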